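The compounds below may be only part of what the source reports. "The series", "measured", "known", "first", "only" and "open" are said of these compounds alone.

Measured compounds:
Compound 1, `CN1CCN(CCNCc2cn(-c3ccc(F)cc3F)nc2-c2ccc(Cl)cc2)CC1`, gives 19000 nM in an ADME assay on Huh-7 cells (Homo sapiens) for cytotoxicity; on this read-out higher numbers stand for lower toxicity in this test and lower numbers for higher toxicity in this test.
Compound 2, `CN1CCN(CCNCc2cn(-c3ccc(C(F)(F)F)cc3)nc2-c2ccc(Cl)cc2)CC1`, gives 3000 nM.
Compound 3, `CN1CCN(CCNCc2cn(-c3ccc([N+](=O)[O-])cc3)nc2-c2ccc(Cl)cc2)CC1`, gives 5000 nM.

Compound 1 has the highest number of the three. The steps away from it are a 3.8-fold lower number from compound 1 to compound 3 (0.58 log units; beyond the scatter) and a 6.3-fold lower number from compound 1 to compound 2 (0.80 log units; beyond the scatter); both alter the group on the aromatic nitrogen, and the two larger-number neighbours differ from each other only by a 1.7-fold higher number from compound 2 to compound 3 (0.22 log units; within the scatter).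

Compound 4, `CN1CCN(CCNCc2cn(-c3ccc(F)cc3F)nc2-c2ccccc2Cl)CC1`, keeps that group and instead has 2-chlorophenyl in place of 4-chlorophenyl on an aromatic carbon. Within the data shown here, no measured step touches the chlorophenyl on the aromatic carbon, so none bears directly on this change. With nothing to point either way, the expected step is a 1.1-fold lower number from compound 1 to compound 4 (0.05 log units; within the scatter), none beyond the scatter. Compound 4 is therefore estimated at 17000 nM, with a range from 7000 nM to 40000 nM.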

Compound 4, half-maximal cytotoxic concentration: > 20000 nM
Compound 4 gave a limit, no number; the forecaster's own chance of this, stated with the estimate: 10%; middle value at least 1.1-fold (0.07 log units) away from the limit.
By their numbers in this assay, from the lowest: compounds 2 and 3 (each within the scatter of the next); then compound 1. At a limit, above all of these: compound 4.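

In this assay compound 4 gives a limit and not a number: the limit of > 20000 nM in this assay, at which 1 of the 4 values shown sits. Replacing 4-chlorophenyl with 2-chlorophenyl is the first change shown on this aromatic carbon, and it reads as an at least 1.0-fold higher number from compound 1 to compound 4 (0.02 log units; that floor lies within the scatter). It therefore brings no lower number of the kind seen on the aromatic nitrogen, although the limit does not show how far the number rises.

Still open, going by these compounds, is how an unsubstituted phenyl or a pyridine ring would read on this carbon. Also open, on these data alone, is whether 2-chlorophenyl gives the same result with 4-(trifluoromethyl)phenyl or 4-nitrophenyl on the aromatic nitrogen.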